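The compounds below may be only part of what the source reports. "The series", "measured", "known", "first", "only" and "open" are said of these compounds alone.

Two hydroxamic acids have been measured in an assay on isolated protein for inhibition of protein deacetylase HDAC6 (Homo sapiens), read by fluorescence; a higher number here means a weaker inhibitor, a lower number a stronger inhibitor. Compound 1, `O=C(CCCCC[C@H](NC(=O)[C@@H]1CCCC(=O)N1)C(=O)NC1CCCC1)NO`, carries a cyclic amide group and a cyclopentyl amide at the other end of the chain; in this assay compound 1 gives 31 nM. Compound 2, `O=C(CCCCCCC(=O)Nc1cccc(C(F)(F)F)c1)NO`, presents a simpler arrangement, a straight chain linking the hydroxamic acid to an aromatic amide bearing a trifluoromethyl group; in this assay compound 2 gives 6 nM. Of the two numbers, compound 2 holds the lower one, and its distance from compound 1 lies beyond the usual scatter of such measurements.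

Compound 3, `Cc1cccc(NC(=O)CCCCCCC(=O)NO)c1`, departs from compound 2 in a single place: methyl in place of trifluoromethyl on an aromatic carbon. Going by the values given here, no measured pair shows this exchange, so its effect cannot be read from the data. The shared chain and hydroxamic acid are kept, and a modest step toward a higher number, or none beyond the scatter, is expected. For compound 3 in this assay the value is estimated at 10 nM, with a range from 4 nM to 30 nM. The expected step from compound 2 to compound 3 is therefore a 1.7-fold higher number from compound 2 to compound 3 (0.22 log units; within the scatter).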

Compound 3, half-maximal inhibitory concentration: 22 nM
Estimate against measurement, compound 3: 2.2-fold (0.34 log units) below; the range from low to high includes it.
By their numbers in this assay, from the lowest: compound 2; then compounds 3 and 1 (each within the scatter of the next).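

Replacing trifluoromethyl with methyl on this aromatic carbon, meta to a large group, leads in this assay to a 3.7-fold higher number from compound 2 to compound 3 (0.56 log units; beyond the scatter) and so shows that the number responds to which of these two groups sits at this position, even with the chain and the hydroxamic acid kept the same. Counted by structure, the exchange removes four heavy atoms, three of them fluorine, and brings in one carbon, while neither group has a ring, a hydrogen-bond donor, a hydrogen-bond acceptor or a net charge. The data at hand give no measurement that would explain why the number moves with this exchange.

On these data alone, whether this step is particular to trifluoromethyl remains open, as a single chlorine atom, a methoxy group or a plain hydrogen on the same carbon could place the number close to either compound 2 or compound 3. Also open, as far as these compounds go, is whether the same exchange would give a similar step elsewhere on the ring, or on a compound with a longer chain.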